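Bromo to fluoro on the phenyl ring: an expectation

The compounds below may be only part of what the source reports. "The series", "measured", "known", "first", "only" and "open" are said of these compounds alone.

Compound 1 `O=C(CSc1nnc(-c2ccncc2)n1-c1ccccc1)N/N=C/c1ccccc1`: 18600 nM in a functional assay on HepG2 cells (Homo sapiens) for inhibition, read by MTT assay, with a stated time of 48 h; on this read-out higher numbers stand for weaker inhibition and lower numbers for stronger inhibition
Compound 2 `O=C(CSc1nnc(-c2ccncc2)n1-c1ccccc1)N/N=C/c1ccc(O)cc1`: > 50000 nM, a limit of the assay
Compound 3 `O=C(CSc1nnc(-c2ccncc2)n1-c1ccccc1)N/N=C/c1ccc(Br)cc1`: 5990 nM

In this assay compound 3 has the lowest number shown; the nearest is compound 1, separated by a 3.1-fold lower number from compound 1 to compound 3 (0.49 log units; beyond the scatter). The value of compound 2 is a limit of the assay and not a number. Compound 4 `O=C(CSc1nnc(-c2ccncc2)n1-c1ccccc1)N/N=C/c1ccc(F)cc1` has not yet been measured; it differs from compound 3 by fluoro in place of bromo on an aromatic carbon. Going by the values given here, two measured steps bear on this change, a 3.1-fold lower number from compound 1 to compound 3 (0.49 log units; beyond the scatter) and an at least 8.3-fold lower number from compound 2 to compound 3 (0.92 log units; beyond the scatter), each showing that the bromo compound gives the lower number. Fluoro has no measured counterpart here, so compound 4 is expected to sit between compound 3 and compound 1. The step expected is a 1.8-fold higher number from compound 3 to compound 4 (0.26 log units; within the scatter). Compound 4 is thus estimated to give 11000 nM, within 4000 nM to 30000 nM.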

Compound 4, half-maximal inhibitory concentration: 9330 nM
Compound 4: the middle estimate sits 1.2-fold (0.07 log units) above what was measured; the range from low to high includes it.
By their numbers in this assay, from the lowest: compounds 3, 4 and 1 (each within the scatter of the next, the first and the last beyond it). At a limit, above all of these: compound 2.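

In this assay fluoro in place of bromo gives a 1.6-fold higher number from compound 3 to compound 4 (0.19 log units; within the scatter) and fluoro in place of hydrogen gives a 2.0-fold lower number from compound 1 to compound 4 (0.30 log units; within the scatter) so neither step separates its pair, although compound 1 and compound 3 do lie beyond the scatter of each other. Fluoro in place of hydroxy gives an at least 5.3-fold lower number from compound 2 to compound 4 (0.72 log units; beyond the scatter) and that step rests on a limit of the assay and not a number: the limit of > 50000 nM in this assay, at which 1 of the 4 values shown sits.

The compounds shown leave open how an amine, a carboxylic acid or a methoxy group would behave at this position. They also leave open whether any group here would give a number well below that of compound 3.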